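The source may hold more compounds than are shown below. What is called first, only, known or untested is meant among the compounds shown, and "the series" means these compounds.

Measured so far, in an assay for inhibition of serine/threonine-protein kinase PAK 4 (Homo sapiens), read by FRET and Z'-LYTE, with a stated time of 60 min, tested at 50 uM, in the presence of a further agent that is not named here; a lower number here means a weaker effect, a higher number a stronger effect of the compound at the concentration tested:
Compound 1 `CC(OC(=O)C(C)C)OC(=O)N1CCN(C(=O)c2nc(Nc3cc(C4CC4)[nH]n3)c3cc(Cl)ccc3n2)C[C@H]1C` gives 71.7%.
Compound 2 `C[C@@H]1CN(C(=O)c2nc(Nc3cc(C4CC4)[nH]n3)c3cc(Cl)ccc3n2)CCN1C(=O)OCc1ccccc1` gives 96%.

Going by the values given here, of these two numbers, compound 2 stands highest, and the only step that leads to it, a number 24.3 percentage points higher from compound 1 to compound 2 (beyond the scatter), lies beyond the scatter. Compound 3 `CC(C)OC(=O)N1CCN(C(=O)c2nc(Nc3cc(C4CC4)[nH]n3)c3cc(Cl)ccc3n2)C[C@H]1C` has not yet been tested. It differs from compound 2 in one place: isopropyl in place of benzyl on an oxygen next to a carbonyl group. Among the compounds with values here, the one measured step also changed the group on an oxygen next to a carbonyl group, from 1-((isopropylcarbonyl)oxy)ethyl to benzyl, and gave a modest rise. Within the data shown here, that step is the only guide available, and it concerns a different pair of groups, so it cannot be carried over directly. Because compound 2 already sits close to the top of what a percentage of inhibition can show at 96%, a move downward is more likely than a further gain, and a small to modest drop is expected, a number 11 percentage points lower from compound 2 to compound 3 (beyond the scatter). Compound 3 is therefore expected to give about 85% in this assay, within 65% to 98%.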

Compound 3, a percentage reported as inhibition, at one concentration (the size of the read-out at that concentration, not a potency) in the serine/threonine-protein kinase PAK 4 assay: 91.2%
Compound 3: the middle estimate sits 6.2 percentage points below what was measured, and the stated range covers the measured number.
By their numbers in the serine/threonine-protein kinase PAK 4 assay, from the lowest: compound 1; then compounds 3 and 2 (each within the scatter of the next).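

In the serine/threonine-protein kinase PAK 4 assay the ringless isopropyl serves about as well as benzyl on this oxygen next to a carbonyl group (a number 4.8 percentage points lower from compound 2 to compound 3 (within the scatter)), so the aromatic ring is not required for this level of inhibition at the concentration tested. Methyl in place of (isopropylcarbonyl)oxy on the saturated chain carbon gives a number 19.5 percentage points higher from compound 1 to compound 3 (beyond the scatter), so the lower reading of compound 1 goes with its (isopropylcarbonyl)oxy group and not with the absence of a ring. In a physicochemical assay, read by HPLC, in phosphate buffer, with a stated time of 2 h, at pH 7.4 (a lower number here means that less of the compound is left, a higher number that more of the compound is left), compound 2 gives 97.7% and compound 3 gives 99%, and the swap leaves this read-out within the scatter (a number 1.3 percentage points higher from compound 2 to compound 3 (within the scatter)).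

On these data alone, whether a longer chain or a chain carrying an amine would hold the inhibition at this place stays open, and readings this near the top at one concentration cannot separate the potencies of compound 2 and compound 3. Nothing shown here explains these results.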